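Carboxymethyl in place of 1-carboxy-1-methylethyl: solubility note

The source may hold more compounds than are shown below. What is called first, only, known or untested is meant among the compounds shown, and "the series" means these compounds.

Within the data shown here, compound 1 `CC(C)(NC(=O)Nc1ccc(F)c(C(F)(F)F)c1)C(=O)O` is the only compound with a number in a physicochemical assay for solubility, read by nephelometry, measured as kinetic solubility, at pH 2, tested at 10 mg/mL; a lower number here means a less soluble compound, a higher number a more soluble compound; in this assay compound 1 gives 25 ug/mL. Compound 2 `CC(C)(NC(=O)Nc1ccccc1)C(=O)O` reaches the limit of this assay, > 100 ug/mL, so no number is known for it (the limit of > 100 ug/mL in this assay, at which 1 of the 2 values shown sits). Compound 3 `O=C(O)CNC(=O)Nc1ccc(F)c(C(F)(F)F)c1` differs from compound 1 by carboxymethyl in place of 1-carboxy-1-methylethyl on an amide-type nitrogen. Among the measured compounds shown here, no step between measured compounds is available; the step is expected to be small, toward higher solubility, possibly no larger than the scatter. Compound 3 is estimated at 50 ug/mL, within 20 ug/mL to 100 ug/mL, which means an expected 2.0-fold higher number from compound 1 to compound 3 (0.30 log units; within the scatter).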

Compound 3, solubility: > 100 ug/mL
Compound 3: only a limit was reported (the forecaster's own chance of this, stated with the estimate: 30%); at least 2.0-fold (0.30 log units) between middle value and limit.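

In this assay, carboxymethyl in place of 1-carboxy-1-methylethyl on an amide-type nitrogen gives an at least 4.0-fold higher number from compound 1 to compound 3 (0.60 log units; beyond the scatter). With the rest of the core of compound 1 unchanged, this single change moves the read-out beyond the scatter, the first such step read at this position. Compound 3 gives > 100 ug/mL, a limit of the assay and not a number: the limit of > 100 ug/mL in this assay, at which 2 of the 3 values shown sit.

As far as these compounds go, the full size of the step stays open. Also open, from the compounds shown here alone, is how a longer chain ending in a carboxylic acid, or an amine in place of that acid, would read at this position in this assay.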